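Lengthening the Linker: Expected Cytotoxicity of Compound 3

The compounds below may be only part of what the source reports. "The series", "measured", "known", "first", "only" and "open" are said of these compounds alone.

Measured so far:
compound 1 `N=C(N)c1ccc2oc(-c3cccc(OCCCCOc4ccccc4)c3)cc2c1` gives 8100 nM
compound 2 `c1ccc(OCCCCOc2cccc(-c3cc4cc(C5=NCCN5)ccc4o3)c2)cc1` gives 9500 nM

Both compounds were tested in an ADME assay on L6 cells (Rattus norvegicus) for cytotoxicity, read by resazurin assay, with a stated time of 70 h; on this read-out higher numbers stand for weaker inhibition and lower numbers for stronger inhibition. Compound 1 and compound 2 share the same core and the same four-carbon chain between the two ring oxygens; they differ only in the group on the aromatic carbon, and that step, a 1.2-fold higher number from compound 1 to compound 2 (0.07 log units; within the scatter), stays within the scatter, so the two numbers cannot be told apart.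

Compound 3 `c1ccc(OCCCCCOc2cccc(-c3cc4cc(C5=NCCN5)ccc4o3)c2)cc1` is the next compound. It keeps the group that compound 2 carries and changes only the chain: phenoxymethyl in place of phenoxy on a saturated chain carbon, four bonds along the chain from an oxygen on an aromatic ring. Going by the values given here, no measured step touches the chain; the single step that exists changes a different part of the molecule and was itself within the scatter. Nothing in the data therefore points to a change in either direction for this assay, and the expectation is a step of no more than the usual scatter.

Compound 3 is expected to give about 9500 nM in this assay, with a likely range from 4500 nM to 20000 nM. That estimate means a step of no change at the digits printed from compound 2 to compound 3 (within the scatter), which is expected to stay within the scatter.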

Compound 3, half-maximal inhibitory concentration: 2600 nM
Estimate against measurement, compound 3: 3.7-fold (0.56 log units) above; measured number outside the range, below it.
By their numbers in this assay, from the lowest: compound 3; then compounds 1 and 2 (each within the scatter of the next).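

In this assay, the chain turns out to be a place where a small change counts: phenoxymethyl in place of phenoxy on a saturated chain carbon, four bonds along the chain from an oxygen on an aromatic ring, gives a 3.7-fold lower number from compound 2 to compound 3 (0.56 log units; beyond the scatter). The swap adds little, with the same ring, the same count of hydrogen-bond donors and acceptors and no net charge, yet this modest step lies beyond the scatter, whereas the earlier change on the aromatic carbon, a 1.2-fold higher number from compound 1 to compound 2 (0.07 log units; within the scatter), did not. Nothing available explains why this one change lowers the number.

From the compounds shown here alone, this single step cannot show a trend, so it remains open whether a longer chain, such as 5-phenoxypentyl in place of 4-phenoxybutyl, would lower the number further, leave it unchanged or raise it again. Going by these compounds, it is also open how this position would respond to a different kind of group, such as an amine or a carboxylic acid in place of the phenoxy end of the chain.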